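Hepatocyte clearance notes: formyl piperidine amide variant

The source may hold more compounds than are shown below. What is called first, only, known or untested is meant among the compounds shown, and "the series" means these compounds.

Measured so far:
compound 1, `O=C(N[C@H]1CN(S(=O)(=O)c2ccccc2)C[C@@H]1C(=O)N[C@H]1CCCNC1)c1ccc(-c2cc(C(F)(F)F)ccc2Cl)o1`: 4.7 uL/min
compound 2, `O=C(N[C@H]1CN(S(=O)(=O)c2ccccc2)C[C@@H]1C(=O)N1C[C@H]2CCNC[C@H]21)c1cc(-c2ccccc2Cl)on1`: 4.7 uL/min

In an ADME assay on cells (Hepatocyte, Rattus norvegicus) for metabolic stability (on this read-out higher numbers stand for fast clearance and lower numbers for slow clearance), compound 1 gives 4.7 uL/min and compound 2 gives 4.7 uL/min; compound 2 stands level with compound 1 at the digits printed, and the two values lie within the scatter of each other. For the measured compounds named here, no step between measured compounds is known for this change.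

Compound 3, `O=CN1CCC[C@H](NC(=O)[C@H]2CN(S(=O)(=O)c3ccccc3)C[C@@H]2NC(=O)c2cc(-c3ccccc3Cl)on2)C1`, differs from compound 2 by a group of 9 heavy atoms (6 carbon, 2 nitrogen, 1 oxygen; one six-membered non-aromatic ring with 1 hetero atom) in place of a group of 8 heavy atoms (6 carbon, 2 nitrogen; one four-membered non-aromatic ring with 1 hetero atom, one six-membered non-aromatic ring with 1 hetero atom), on a carbonyl carbon on a carbonyl carbon. Going by the values given here, with no measured step to draw on, the step of a 1.1-fold higher number from compound 2 to compound 3 (0.03 log units; within the scatter) is expected to stay within the scatter, in no clear direction. Compound 3 is therefore estimated at 5 uL/min in this assay, with a range from 2.5 uL/min to 10 uL/min.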

Compound 3, intrinsic clearance in a liver preparation (reported as CLH), per the amount of preparation that the assay uses in the Hepatocyte assay: 97 uL/min
Compound 3: the middle estimate sits 19-fold (1.29 log units) below what was measured; the whole stated range lies below it.
By their numbers in the Hepatocyte assay, from the lowest: compounds 1 and 2 (each within the scatter of the next); then compound 3.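

The group on this carbonyl carbon is not neutral for clearance: in the Hepatocyte assay, the group with one six-membered non-aromatic ring, in place of the group with four-membered and six-membered rings, gives a 21-fold higher number from compound 2 to compound 3 (1.31 log units; beyond the scatter). In a physicochemical assay for solubility, at pH 7.4 (a lower number here means a less soluble compound, a higher number a more soluble compound), compound 2 gives 265000 nM and compound 3 gives 4500 nM, so this single change separates the pair on both read-outs.

For the compounds shown here, the one pair cannot tell whether the formyl group or the loss of the four-membered ring drives either step. An amine or an acetyl group in place of the formyl group would help separate the two.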